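Swapping chloro for methoxy on the anilide ring of a caffeate ester

A few compounds are considered here, and "the series" means these few. Any claim that something is new, unique, unknown or untested is made for them only; others in the source may bear on it.

The series consists of compound 1 `COc1ccc(NC(=O)COC(=O)/C=C/c2cc(OC)c(OCc3ccc(Cl)c(Cl)c3)c(OC)c2)cc1`, compound 2 `COc1cc(/C=C/C(=O)OCC(=O)Nc2ccc(Cl)cc2)cc(OC)c1OCc1ccc(Cl)c(Cl)c1`, compound 3 `O=C(COC(=O)/C=C/c1ccc(O)c(O)c1)Nc1ccc(Cl)cc1` and compound 4 `COc1ccc(NC(=O)COC(=O)/C=C/c2ccc(O)c(O)c2)cc1`. Three of them were tested in a functional assay on LS174T cells (Homo sapiens) for cytotoxicity, read by MTT assay, with a stated time of 72 h; a lower number here means a stronger inhibitor, a higher number a weaker inhibitor. Compound 2 gives 72400 nM. Compound 3 gives 108000 nM, which sits close to compound 2. For compound 1 the assay reports only a limit, > 200000 nM, so the limit of > 200000 nM in this assay, at which 1 of the 3 values shown sits, is all that is known of it. The difference between compound 2 and compound 1 is methoxy in place of chloro on an aromatic carbon, and it produced an at least 2.7-fold higher number from compound 2 to compound 1 (0.44 log units; beyond the scatter). The difference between the cores of compound 3 and compound 2 is not broken down here. Compound 4 differs from compound 3 by methoxy in place of chloro on an aromatic carbon, the same change as between compound 2 and compound 1, and at the same place. On the strength of that earlier step, compound 4 is expected to show a 2.3-fold higher number from compound 3 to compound 4 (0.36 log units; beyond the scatter), a weakening of similar size. Compound 4 is therefore estimated at 250000 nM, within 110000 nM to 600000 nM, with a real chance that only a limit is reported.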

Compound 4, half-maximal inhibitory concentration: 124000 nM
Compound 4: middle estimate off by 2.0-fold (0.30 log units), on the high side, within the range that was stated.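

In this assay, the change from 4-chlorophenyl to 4-methoxyphenyl on the core of compound 3 gave a 1.1-fold higher number from compound 3 to compound 4 (0.06 log units; within the scatter), so on this core the swap made no difference that can be told from the scatter. Set beside the same swap on the core of compound 2, the result reads: the same change on two cores in this assay, an at least 2.7-fold higher number (0.44 log units; beyond the scatter) from compound 2 to compound 1 and a 1.1-fold higher number (0.06 log units; within the scatter) from compound 3 to compound 4; the limit leaves it open whether they differ. Compound 1 is known only through a limit, > 200000 nM, so the data show neither that the change carries over from one core to the other with the same size nor that its size depends on the core.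

A measured number for compound 1 in place of that limit would be needed to compare the two steps. The compounds shown leave open how an amine or a carboxylic acid in place of the chloro would read in this assay on either core, and whether a further core would follow either of the two steps.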